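Chloro for fluoro in two matched pairs

The compounds below may be only part of what the source reports. "The series", "measured", "known", "first", "only" and "open" are said of these compounds alone.

Measured compounds:
compound 1 `CCCC(=O)Nc1cccc(NC(=O)c2ccccc2F)c1`, 970 nM
compound 2 `CCCC(=O)Nc1cccc(NC(=O)c2ccccc2Cl)c1`, 1100 nM
compound 3 `CCCC(=O)Nc1cccc(NC(=O)c2cc(F)ccc2Br)c1`, 600 nM

In an assay on a cell-free system (plasma) for inhibition of proteinase-activated receptor 1 (Homo sapiens), read by flow cytometry, with a stated time of 20 min (a higher number here means a weaker inhibitor, a lower number a stronger inhibitor), compound 1 and compound 2 differ by chloro in place of fluoro on an aromatic carbon, and this change gave a 1.1-fold higher number from compound 1 to compound 2 (0.05 log units; within the scatter). The difference between the core of compound 1 and the core of compound 3 is not broken down here. Compound 4 `CCCC(=O)Nc1cccc(NC(=O)c2cc(Cl)ccc2Br)c1`, not yet measured, relates to compound 3 by chloro in place of fluoro on an aromatic carbon. This is the same kind of change as the first pair, not the same: in the first pair the place is ortho to a large group, while here it is meta to a large group and para to a bromo group. For compound 4 the expected step in this assay is a 1.1-fold higher number from compound 3 to compound 4 (0.03 log units; within the scatter), resting on compound 1 to compound 2 giving a 1.1-fold higher number from compound 1 to compound 2 (0.05 log units; within the scatter). Compound 4 is estimated at 650 nM, with a range of 300 nM to 1400 nM.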

Compound 4, half-maximal inhibitory concentration: 380 nM
Beside the measured number, compound 4's estimate is 1.7-fold (0.23 log units) above it; the range from low to high includes it.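

Chloro in place of fluoro has now been read on two cores in this assay, and the new step is a 1.6-fold lower number from compound 3 to compound 4 (0.20 log units; within the scatter). Set beside the earlier step, it does not differ: the same change on two cores in this assay, a 1.1-fold higher number (0.05 log units; within the scatter) from compound 1 to compound 2 and a 1.6-fold lower number (0.20 log units; within the scatter) from compound 3 to compound 4, 1.8-fold (0.25 log units) apart, within the scatter of two such steps. The change therefore carries across these two cores without a step that stands out from the scatter, but two pairs cannot show that this would hold on a further core or at another place on the ring.

The aromatic ring bearing the changed group carries only halogens in the compounds shown. Open, from the compounds shown here alone, is whether an amine or a carboxylic acid on that ring, or a longer chain in place of the chain on the other amide, would move the number beyond the scatter.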